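Following a Benzyl Exchange from Compound 2 to Compound 3

A few compounds are considered here, and "the series" means these few. Any claim that something is new, unique, unknown or untested is made for them only; others in the source may bear on it.

Two measured compounds open the account. Compound 1 `Cc1ccc(-c2nn(-c3ccccc3)cc2C(=O)NOCc2ccc(Cl)cc2Cl)cc1` and compound 2 `COc1ccc(-c2nn(-c3ccccc3)cc2C(=O)NOCc2ccccc2F)cc1` share a core and differ in two places. In a functional assay on A549 cells (Homo sapiens) for antiproliferative activity, read by MTT assay, with a stated time of 48 h, in the presence of a further agent that is not named here (on this read-out higher numbers stand for weaker inhibition of growth and lower numbers for stronger inhibition of growth), compound 1 gives 1080 nM. In this assay compound 2 gives 2160 nM, the higher of the two numbers, though its gap to compound 1 is within the usual scatter, so no order between them can be claimed. Compound 3 `COc1ccc(-c2nn(-c3ccccc3)cc2C(=O)NOCc2ccc(Cl)cc2Cl)cc1` is not yet measured. It keeps the methoxy side of compound 2 and carries the change (2,4-dichlorophenyl in place of 2-fluorophenyl on a saturated chain carbon bound to an oxygen), which brings in the group that compound 1 already bears. Within the data shown here, no step between measured compounds covers this change alone. Because compound 1 gives 1080 nM with the same entering group, a small move toward a lower number is expected. The step of a 1.5-fold lower number from compound 2 to compound 3 (0.19 log units; within the scatter) is expected to remain within the scatter. Compound 3 is estimated at 1400 nM, with a range from 600 nM to 3500 nM.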

Compound 3, concentration for 50% growth inhibition: 3830 nM
Compound 3: middle estimate off by 2.7-fold (0.44 log units), on the low side; the measured number lies above the stated range.
By their numbers in this assay, from the lowest: compounds 1, 2 and 3 (each within the scatter of the next, the first and the last beyond it).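

With the methoxy side held fixed, 2,4-dichlorophenyl in place of 2-fluorophenyl on a saturated chain carbon bound to an oxygen gives a 1.8-fold higher number from compound 2 to compound 3 (0.25 log units; within the scatter) in this assay, so this exchange alone shows no clear effect on the number. With 2,4-dichlorobenzyl held fixed, methoxy in place of methyl on an aromatic carbon gives a 3.5-fold higher number from compound 1 to compound 3 (0.55 log units; beyond the scatter), which makes this the only single change shown that lies beyond the scatter. Nothing available explains either step.

The compounds shown leave open whether the exchange of methyl for methoxy gives a similar step when 2-fluorobenzyl is the group on the chain. They also leave open how an amine, a carboxylic acid or a longer chain would read on that same aromatic carbon.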